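A few compounds are considered here, and "the series" means these few. Any claim that something is new, unique, unknown or untested is made for them only; others in the source may bear on it.

Measured so far in a functional assay on PC-3 cells (Homo sapiens) for inhibition, read by sulforhodamine B assay; on this read-out higher numbers stand for weaker inhibition of growth and lower numbers for stronger inhibition of growth:
- Compound 1 (`O=C(CCC1=CCCN(Cc2ccc(F)cc2)C1=O)NO`): "not determined" (no result reported) for this compound
- Compound 2 (`CC(=O)Nc1ccc(CN2CCC=C(CCC(=O)NO)C2=O)cc1`): > 10000 nM as a limit of the assay, not a number
- Compound 3 (`Cc1ccc(CN2CCC=C(CCC(=O)NO)C2=O)cc1`): 8100 nM as a measured number

Among the compounds with values here, compound 3 holds the only true number here; the other two entries are a limit and a missing result. The change methoxy in place of methyl on an aromatic carbon turns compound 3 into compound 4 (`COc1ccc(CN2CCC=C(CCC(=O)NO)C2=O)cc1`), with methoxy in place of methyl on an aromatic carbon. Within the data shown here, the one measured step that bears on it is an at least 1.2-fold lower number from compound 2 to compound 3 (0.09 log units; that floor lies within the scatter) and it put methyl in place of acetamido on an aromatic carbon. Among the measured compounds shown here, with only that guide, no step beyond the scatter is expected in this assay and no direction can be favoured. The estimated step is a 1.1-fold lower number from compound 3 to compound 4 (0.03 log units; within the scatter) in size. For compound 4 the expected value is 7500 nM with an estimated range from 3000 nM to 15000 nM at its ends.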

Compound 4, concentration for 50% growth inhibition: 7080 nM
Compound 4: the middle estimate sits 1.1-fold (0.03 log units) above what was measured; measured number inside the range.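

In this assay, methyl and methoxy can now be compared directly as measured numbers on an aromatic carbon para to a large group, and exchanging them gives a 1.1-fold lower number from compound 3 to compound 4 (0.06 log units; within the scatter). Methoxy in place of acetamido gives an at least 1.4-fold lower number from compound 2 to compound 4 (0.14 log units; that floor lies within the scatter). That step can be read only as a floor because compound 2 carries a limit of the assay, not a number: the limit of > 10000 nM in this assay, at which 1 of the 4 values shown sits.

The compounds shown leave open whether an amine or a carboxylic acid at this position would shift the number beyond the scatter.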